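Removing One Methoxy Group: Expected Effect on Cytotoxicity

This account rests on a few compounds, and the source may have more. Where it says the series, first, only, none or still open, it means among the compounds named here.

Compound 1 `C=CC1=C(C(=O)O)C(c2ccc(OC)cc2)OC1` gives > 100000 nM in a functional assay on A549 cells (Homo sapiens) for cytotoxicity, read by MTT assay, with a stated time of 24 h (on this read-out lower numbers stand for stronger inhibition and higher numbers for weaker inhibition), which is a limit of the assay rather than a number.
Compound 2 `C=CC1=C(C(=O)NC(C)(C)C)C(c2ccc(OC)cc2)OC1` gives > 100000 nM in this assay, again a limit.
Compound 3 `C=CC1=C(C(=O)NC2CCCCC2)C(c2ccc(OC)c(OC)c2)OC1` gives > 100000 nM in this assay, again a limit.

Compound 3 therefore stands where every measured compound stands: at the limit, with no number to rank it against the others. Within the data shown here, the one single-point step, from compound 1 to compound 2 a step that the two limits leave unreadable from compound 1 to compound 2, exchanges hydroxy for (tert-butyl)amino on a carbonyl carbon, and its size cannot be read. Compound 2 and compound 3 differ in more than one place, so only their two limits can be compared, and both are limits.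

Compound 4 `C=CC1=C(C(=O)NC2CCCCC2)C(c2ccc(OC)cc2)OC1` differs from compound 3 by hydrogen in place of methoxy on an aromatic carbon. Among the measured compounds shown here, no measured step isolates this change. Because (the limit of > 100000 nM in this assay, at which 3 of the 3 values shown sit), the expectation is that compound 4 also reaches only the limit, with a step that the limit leaves unreadable from compound 3 to compound 4 that is expected to mean nothing beyond the scatter. Compound 4 is estimated at 150000 nM, within 50000 nM to 500000 nM.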

Compound 4, half-maximal inhibitory concentration: > 100000 nM
Compound 4: only a limit was reported; the forecaster's own chance of this, stated with the estimate: 85%; the middle value lies beyond the limit too.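

In this assay compound 4 gives > 100000 nM as a limit of the assay, not a number. The steps joining compound 4 to compound 1, compound 2 and compound 3 therefore cannot be read. The four compounds leave open which single change, if any, would affect cytotoxicity.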